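The source may hold more compounds than are shown below. What is called first, only, known or untested is meant among the compounds shown, and "the series" means these compounds.

In a functional assay on RXF 393 cells (Homo sapiens) for inhibition, read by sulforhodamine B assay, with a stated time of 48 h, tested at 10 uM (on this read-out higher numbers stand for more inhibition of growth at the one concentration tested and lower numbers for less inhibition of growth), compound 1 `c1ccc(-c2nc3sc(-c4ccccc4)cn3n2)cc1` gives 9%. Compound 2 `COc1ccc(-c2nc3sc(-c4ccc(Cl)cc4)cn3n2)cc1` gives 41% in this assay, the higher of the two numbers measured, with compound 1 lying lower by more than the usual scatter. Compound 3 `Clc1ccc(-c2cn3nc(-c4ccccc4)nc3s2)cc1` differs from compound 2 in one place: hydrogen in place of methoxy on an aromatic carbon. Within the data shown here, no measured pair shows this change on its own. A moderate downward step a number 16 percentage points lower from compound 2 to compound 3 (beyond the scatter) is expected because compound 1 gives 9%. Compound 3 is therefore estimated at 25%, with a range from 5% to 45%.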

Compound 3, percent growth inhibition at one concentration: 39%
Compound 3: middle estimate off by 14 percentage points, on the low side, within the range that was stated.
By their numbers in this assay, from the lowest: compound 1; then compounds 3 and 2 (each within the scatter of the next).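

In this assay, hydrogen in place of methoxy on this aromatic carbon, para to a large group, gives a number 2 percentage points lower from compound 2 to compound 3 (within the scatter), so this read-out does not separate the two groups here. Chloro in place of hydrogen on an aromatic carbon gives a number 30 percentage points higher from compound 1 to compound 3 (beyond the scatter), so of the two single changes, only this one carries a step beyond the scatter. Nothing measured here accounts for either step. From the compounds shown here alone, what an amine or a carboxylic acid at the methoxy position would give stays open.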